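Trifluoromethyl for methyl on the shared core of compound 2

The source may report more compounds than this note shows. Statements on the series, on what has been measured and on what is new or still open speak of the compounds shown alone.

Among the measured compounds shown here, in an assay on HEK293 cells for inhibition of sodium-dependent dopamine transporter (Homo sapiens), read by scintillation counting, with stated times of 5 min and 1 min (on this read-out lower numbers stand for stronger inhibition and higher numbers for weaker inhibition), compound 1 `Cc1noc(C[S+]([O-])C(c2ccccc2)c2ccccc2)n1` gives 56700 nM and compound 2 `Cc1cc(O)nc(C[S+]([O-])C(c2ccccc2)c2ccccc2)n1` gives 109000 nM; the single step recorded, a 1.9-fold higher number from compound 1 to compound 2 (0.28 log units; within the scatter), concerns a heteroaryl exchange. Compound 2 thus carries the higher of the two numbers, though its distance to compound 1 is within the scatter. Compound 3 `[O-][S+](Cc1nc(O)cc(C(F)(F)F)n1)C(c1ccccc1)c1ccccc1` differs from compound 2 by trifluoromethyl in place of methyl on an aromatic carbon. For the measured compounds named here, no measured step touches this change, so nothing supports a shift beyond the scatter in this assay. Compound 3 is expected to give 100000 nM (range 40000 nM to 300000 nM), corresponding to an estimated step of a 1.1-fold lower number from compound 2 to compound 3 (0.04 log units; within the scatter).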

Compound 3, half-maximal inhibitory concentration: 40400 nM
Beside the measured number, compound 3's estimate is 2.5-fold (0.39 log units) above it; low and high end bracket the measured number.
By their numbers in this assay, from the lowest: compounds 3, 1 and 2 (each within the scatter of the next, the first and the last beyond it).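

In this assay, trifluoromethyl in place of methyl on this aromatic carbon, next to the ring nitrogen, gives a 2.7-fold lower number from compound 2 to compound 3 (0.43 log units; beyond the scatter), a modest step but the first in the series beyond the scatter. This position therefore responds to a change of group, whereas the heteroaryl exchange, a 1.9-fold higher number from compound 1 to compound 2 (0.28 log units; within the scatter), stayed within the scatter. Nothing at hand explains the step.

As far as these compounds go, what a chlorine atom, an amine or an ethyl chain would do on this aromatic carbon stays open. Also open, from the compounds shown here alone, is whether trifluoromethyl for methyl moves the number the same way on another core.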